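This account rests on a few compounds, and the source may have more. Where it says the series, first, only, none or still open, it means among the compounds named here.

Measured so far in an assay on CHO cells for activation of Guanylate cyclase soluble subunit alpha-1 (Rattus norvegicus), read by luminescence and cGMP accumulation, with a stated time of 6 min; on this read-out lower numbers stand for smaller maximal responses and higher numbers for larger maximal responses:

- compound 1, `C[C@H]([C@H](C(=O)Nc1cc(CC2(C(=O)O)CC2)ccc1Cl)c1ccc(Cl)cc1)C(F)(F)F`: 63%
- compound 2, `Cc1ccc(CC2(C(=O)O)CC2)cc1NC(=O)[C@H](c1ccc(Cl)cc1)[C@@H](C)C(F)(F)F`: 44%

Compound 1 holds the higher of these two numbers. Going by the values given here, its only neighbour is compound 2, and the single measured step, a number 19 percentage points lower from compound 1 to compound 2 (beyond the scatter), comes with methyl in place of chloro on an aromatic carbon. That step lies beyond the scatter but is still modest in size.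

The next compound, compound 3, has the structure `C[C@H]([C@H](C(=O)Nc1cc(C2(CC(=O)O)CCC2)ccc1Cl)c1ccc(Cl)cc1)C(F)(F)F`. It differs from compound 1 in one place: 1-(carboxymethyl)cyclobutyl in place of (1-carboxycyclopropyl)methyl on an aromatic carbon. The acid-bearing side chain is thus rebuilt, while the rest of the molecule, including the chloro group that was exchanged in the step to compound 2, is left untouched.

Among the compounds with values here, no measured step touches this part of the molecule, so nothing in the data speaks directly to the size or direction of the change. Within the data shown here, the one measured step shows that a small change elsewhere moved this assay only modestly. On that basis, compound 3 is expected to come out near compound 1, with a step of a number 8 percentage points lower from compound 1 to compound 3 (within the scatter), and its estimated value is 55%, in a range from 35% to 75%.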

Compound 3, largest response reached (reported as efficacy), in percent of the reference or control that the assay uses: 37%
Compound 3: middle estimate off by 18 percentage points, on the high side; measured number inside the range.
By their numbers in this assay, from the lowest: compounds 3 and 2 (each within the scatter of the next); then compound 1.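

The position on the aromatic carbon para to a chloro group is sensitive to how the acid-bearing side chain is built in this assay: putting 1-(carboxymethyl)cyclobutyl in place of (1-carboxycyclopropyl)methyl gives a number 26 percentage points lower from compound 1 to compound 3 (beyond the scatter) and lies beyond the scatter. Both groups carry a carboxylic acid and have the same hydrogen-bond donor and acceptor counts, so this step shows that keeping the acid is not enough to preserve the maximal response of compound 1, and that a rebuild of the chain around it can lower that response on its own. No measurement at hand explains why this rebuild lowers the response.

The swap changes several things at once: the ring goes from three-membered to four-membered, the heavy-atom count goes from 7 to 8, and the ring sits at a different point in the chain, so these effects cannot be separated here. A 1-(carboxymethyl)cyclopropyl group or a (1-carboxycyclobutyl)methyl group at the same position would change only one of these features, and a tetrazole in place of the carboxylic acid remains an open question.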